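Chain shortening at the amino side: cytotoxicity notes

The source may report more compounds than this note shows. Statements on the series, on what has been measured and on what is new or still open speak of the compounds shown alone.

compound 1, `CCCCCCNc1cncc(C(=O)NCc2ccccc2)n1`: > 100000 nM
compound 2, `CCCCNc1nccnc1C(=O)NCc1ccccc1`: > 100000 nM

In an ADME assay on HEL cells (Homo sapiens) for cytotoxicity, read by microscopy, with a stated time of 6 days (on this read-out higher numbers stand for lower toxicity in this test and lower numbers for higher toxicity in this test), compound 1 reaches only a limit of the assay, > 100000 nM, and gives no number. Compound 2 likewise stops at a limit, > 100000 nM. Both measured values thus sit at the limit of > 100000 nM in this assay, at which 2 of the 2 values shown sit, so compound 1 stands nowhere above or below its one companion. Compound 3, `CCCCNc1cncc(C(=O)NCc2ccccc2)n1`, differs from compound 1 by hydrogen in place of ethyl on a saturated chain carbon, four bonds along the chain from a nitrogen on an aromatic ring. Among the compounds with values here, no measured step exists to lean on; no step beyond the scatter is expected, a step that the limit leaves unreadable from compound 1 to compound 3, with both measured compounds at the limit (the limit of > 100000 nM in this assay, at which 2 of the 2 values shown sit). Compound 3 is expected at 150000 nM (range 50000 nM to 500000 nM), most likely again reported only as a limit.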

Compound 3, minimum cytotoxic concentration: > 100000 nM
Compound 3 ended at the assay's limit; the forecaster's own chance of this, stated with the estimate: 90%; the middle value does not contradict the limit.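

Compound 1 and compound 3 both stop at a limit of the assay, so no step can be read between them. The compounds shown leave open whether chain length affects the result in this assay at all, since none gives a number.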